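Working notes on the Ret series: compound 4 estimate

The source may report more compounds than this note shows. Statements on the series, on what has been measured and on what is new or still open speak of the compounds shown alone.

Compound 1 `CC(C)n1nc(-c2cc(-c3ccccc3)on2)c(C(N)=O)c1N`: 236 nM in an assay on isolated protein for inhibition of proto-oncogene tyrosine-protein kinase receptor Ret (Homo sapiens), read by radiometric assay and 33P incorporation, in the presence of a further agent that is not named here; on this read-out lower numbers stand for stronger inhibition and higher numbers for weaker inhibition
Compound 2 `Cc1ccc(-c2cc(-c3nn(C(C)C)c(N)c3C(N)=O)no2)cc1`: 1660 nM
Compound 3 `CC(C)c1cc(-c2nn(C(C)C)c(N)c2C(N)=O)no1`: 1260 nM

Compound 2 stands highest of the three numbers: a 7.0-fold higher number from compound 1 to compound 2 (0.85 log units; beyond the scatter) lies beyond the scatter, whereas a 1.3-fold lower number from compound 2 to compound 3 (0.12 log units; within the scatter) lies within it. Compound 4 `CC(C)n1nc(-c2cc(C3CC3)on2)c(C(N)=O)c1N` differs from compound 2 by cyclopropyl in place of 4-methylphenyl on an aromatic carbon. The step that bears on it most is a 1.3-fold lower number from compound 2 to compound 3 (0.12 log units; within the scatter), where a non-aromatic group also replaced 4-methylphenyl with no change beyond the scatter; a 5.3-fold higher number from compound 1 to compound 3 (0.73 log units; beyond the scatter) shows that trading phenyl for a non-aromatic group gave a modest rise. Cyclopropyl, being likewise non-aromatic, is expected to behave like isopropyl, so the step from compound 2 to compound 4 is estimated at a 1.3-fold lower number from compound 2 to compound 4 (0.11 log units; within the scatter), within the scatter. Compound 4 is therefore expected to give about 1300 nM in this assay, in the range 500 nM to 3500 nM.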

Compound 4, half-maximal inhibitory concentration: 44 nM
Compound 4: the middle estimate sits 30-fold (1.47 log units) above what was measured; the whole stated range lies above it.
By their numbers in this assay, from the lowest: compound 4; then compound 1; then compounds 3 and 2 (each within the scatter of the next).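

At the aromatic carbon next to the ring oxygen, non-aromatic groups do not behave alike: a 29-fold lower number from compound 3 to compound 4 (1.46 log units; beyond the scatter) separates cyclopropyl from isopropyl, and a 38-fold lower number from compound 2 to compound 4 (1.58 log units; beyond the scatter) shows that replacing 4-methylphenyl can matter far more than compound 3 suggested. With a 5.4-fold lower number from compound 1 to compound 4 (0.73 log units; beyond the scatter), cyclopropyl also outperforms phenyl, so compound 4 has the lowest number of the four. No measurement shown here accounts for the difference between these groups. Open, as far as these compounds go, is how a cyclobutyl ring, a methyl group or an amine would read at this carbon, and whether the cyclopropyl result holds with other changes on the shared core.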